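Swapping Dichlorophenyl for Methoxyphenyl in a Cytotoxic Series

The source may report more compounds than this note shows. Statements on the series, on what has been measured and on what is new or still open speak of the compounds shown alone.

Measured in a functional assay on MCF7 cells (Homo sapiens) for cytotoxicity, read by MTT assay, with a stated time of 48 h; on this read-out lower numbers stand for stronger inhibition and higher numbers for weaker inhibition:
- Compound 1 `COc1cc(N2C(=S)SCC2(O)c2ccc(Br)cc2)cc(OC)c1OC`: 16.5 ug/mL
- Compound 2 `COc1cc(-n2c(-c3ccc(Cl)cc3Cl)csc2=S)cc(OC)c1OC`: 23.6 ug/mL
- Compound 3 `COc1cc(-n2c(-c3ccc(-c4ccccc4)cc3)csc2=S)cc(OC)c1OC`: 45.3 ug/mL
- Compound 4 `COc1ccc(-c2csc(=S)n2-c2cc(OC)c(OC)c(OC)c2)cc1`: not yet measured

Repeated measurements of this kind naturally vary a little, so small gaps between values carry no meaning. Compound 2, at 23.6 ug/mL, lies within that usual scatter of both compound 1 and compound 3, and the numbers do not separate it from either.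

Compound 4 is compound 2 with one group exchanged: 4-methoxyphenyl in place of 2,4-dichlorophenyl on an aromatic carbon. The ring being swapped is the same kind in both, a six-membered aromatic ring of carbon only. Among the compounds with values here, no measured pair in this small set differs in one place alone, so the effect of this exchange has not been observed directly. The closest guide is compound 3, which carries a different group in that place and gives 45.3 ug/mL, a value still within the scatter of compound 2. On that slim evidence, no step beyond the scatter is expected in this assay, and no direction can be called with confidence. The expected 1.1-fold higher number from compound 2 to compound 4 (0.03 log units; within the scatter) is therefore small. For compound 4 the estimated value is 25 ug/mL, with an expected range from 10 ug/mL to 60 ug/mL.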

Compound 4, half-maximal inhibitory concentration: > 100 ug/mL
Compound 4: no number, only a limit (the forecaster's own chance of this, stated with the estimate: 10%); middle value at least 4.0-fold (0.60 log units) away from the limit.
By their numbers in this assay, from the lowest: compounds 1, 2 and 3 (each within the scatter of the next, the first and the last beyond it). At a limit, above all of these: compound 4.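

On an aromatic carbon of the five-membered aromatic ring with 1 nitrogen and 1 sulfur, the group matters: in this assay, exchanging 2,4-dichlorophenyl for 4-methoxyphenyl gives an at least 4.2-fold higher number from compound 2 to compound 4 (0.62 log units; beyond the scatter). Within the data shown here, putting methoxy in place of the outer phenyl of the group at this carbon gives an at least 2.2-fold higher number from compound 3 to compound 4 (0.34 log units; beyond the scatter), so 4-methoxyphenyl is set apart from both of the other groups measured at this position, a difference the earlier compounds could not reveal. Compound 4 gives a limit and not a number, so both steps have a floor but no known size: the limit of > 100 ug/mL in this assay, at which 1 of the 4 values shown sits.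

The compounds shown leave open which part of the first exchange counts, as the two chlorines leave and the methoxy enters in a single step; a plain phenyl or a chlorophenyl at this carbon would help to separate the two. Also open, as far as these compounds go, is how a ring carrying a hydroxyl or an amine in place of the methoxy would behave in this assay.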